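Longer hydroxyalkynyl chain replacing hydroxymethyl on the shared core

The compounds below may be only part of what the source reports. "The series", "measured", "known", "first", "only" and "open" are said of these compounds alone.

Of the compounds shown here, two have been tested in an ADME assay on L1210/0 cells (Mus musculus) for cytotoxicity, with a stated time of 48 h; a higher number here means a weaker inhibitor, a lower number a stronger inhibitor. Compound 1, `C#Cc1cn([C@@H]2O[C@H](CO)[C@@H](O)[C@@H]2O)c(=O)[nH]c1=O`, gives 168000 nM. Compound 2, `O=c1[nH]c(=O)n([C@H]2C[C@H](O)[C@@H](CO)O2)cc1CO`, gives 9180 nM, the lower of the two numbers; the gap between compound 2 and compound 1 lies beyond the usual scatter, with compound 2 the stronger of the pair. Within the data shown here, no pair of compounds differing in a single place has been measured, so no single step is yet known.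

Compound 3, `O=c1[nH]c(=O)n([C@H]2C[C@H](O)[C@@H](CO)O2)cc1C#CCCO`, is the next compound to be measured. It differs from compound 2 in one place: 4-hydroxybut-1-yn-1-yl in place of hydroxymethyl on an aromatic carbon.

Among the measured compounds shown here, since no comparable step is available, the expectation for compound 3 rests on compound 2 alone, whose value of 9180 nM serves as the anchor. The step is expected to run upward, toward a weaker inhibitor, by a 5.4-fold higher number from compound 2 to compound 3 (0.74 log units; beyond the scatter). Compound 3 is therefore estimated at 50000 nM, with a range from 10000 nM to 250000 nM.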

Compound 3, half-maximal inhibitory concentration: > 200000 nM
Compound 3: only a limit was reported; the forecaster's own chance of this, stated with the estimate: 10%; at least 4.0-fold (0.60 log units) between middle value and limit.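

In this assay compound 3 gives only a limit, > 200000 nM, and not a number. Among these compounds, replacing hydroxymethyl with 4-hydroxybut-1-yn-1-yl on this aromatic carbon gives an at least 21-fold higher number from compound 2 to compound 3 (1.33 log units; beyond the scatter), the first single change on the shared core that can be read, and it shows that this position is sensitive to the group it carries, with the longer chain leading to a weaker inhibitor here. The full size of the step stays unknown because the number for compound 3 is bounded only on one side: the limit of > 200000 nM in this assay, at which 1 of the 3 values shown sits.

This one step cannot separate the effect of the triple bond from that of the chain length. Going by these compounds, how a shorter hydroxyalkynyl chain, a saturated hydroxyalkyl chain or a chain ending in an amine would read at this position remains open.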